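This account rests on a few compounds, and the source may have more. Where it says the series, first, only, none or still open, it means among the compounds named here.

Working notes, series on the shared core read in a functional assay on CHO cells with adenosine receptor A1 (Homo sapiens) as the target, read by cAMP accumulation and immunoassay, with a stated time of 6 min, tested at 1 uM; on this read-out lower numbers stand for a stronger effect and higher numbers for a weaker effect at the one concentration tested.

Three compounds are measured. Compound 1 `Nc1scc(CN2CCN(c3cc(Cl)cc(Cl)c3)CC2)c1C(=O)c1ccc(Cl)cc1` gives -69%. Compound 2 `Nc1scc(CN2CCN(c3ccc(Cl)c(C(F)(F)F)c3)CC2)c1C(=O)c1ccc(Cl)cc1` gives -47%. Compound 3 `Nc1scc(CN2CCN(c3c(F)cccc3F)CC2)c1C(=O)c1ccc(Cl)cc1` gives -65%. Compound 2 stands highest of the three numbers, that is, the weakest effect at the one concentration: the gap to the nearest is a number 18 percentage points lower from compound 2 to compound 3 (beyond the scatter), and the gap to the furthest is a number 22 percentage points higher from compound 1 to compound 2 (beyond the scatter). Between the other two the step is a number 4 percentage points higher from compound 1 to compound 3 (within the scatter), so they cannot be set in order.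

Compound 4 `Nc1scc(CN2CCN(c3c(F)cc(F)cc3F)CC2)c1C(=O)c1ccc(Cl)cc1` is not yet measured in this assay. The change from compound 2 is 2,4,6-trifluorophenyl in place of 4-chloro-3-(trifluoromethyl)phenyl on an amine nitrogen in a ring. The step that bears on it most directly is the one in which a difluorophenyl enters in place of the same leaving group: a number 18 percentage points lower from compound 2 to compound 3 (beyond the scatter), a modest move beyond the scatter. The step of a number 4 percentage points higher from compound 1 to compound 3 (within the scatter) adds that the two fluorinated and dichlorinated patterns measured so far sit together, apart from compound 2. For compound 4 a step lower, of roughly the size seen on going to compound 3, is therefore expected: a number 15 percentage points lower from compound 2 to compound 4 (beyond the scatter). The estimated value for compound 4 is -62%, with an expected range from -78% to -46%.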

Compound 4, a percentage reported as activity, at one concentration (the size of the read-out at that concentration, not a potency): -56%
For compound 4 the middle estimate is 6 percentage points below the measured one; the range from low to high includes it.
By their numbers in this assay, from the lowest: compounds 1, 3, 4 and 2 (each within the scatter of the next, the first and the last beyond it).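

On the aryl group carried by the ring nitrogen, fluoro in place of hydrogen on an aromatic carbon gives in this assay a step that cannot be separated from no change: a number 9 percentage points higher from compound 3 to compound 4 (within the scatter). The 2,4,6-trifluorophenyl group also fails to separate from the 4-chloro-3-(trifluoromethyl)phenyl group, with a number 9 percentage points lower from compound 2 to compound 4 (within the scatter), yet it does separate from the 3,5-dichlorophenyl group, with a number 13 percentage points higher from compound 1 to compound 4 (beyond the scatter), so compound 2 no longer stands apart as a lone case and the compounds form an overlapping run rather than two clear groups. No measurement at hand accounts for any of these steps.

On these data alone, all the groups at this position are halogen-bearing phenyl rings, so it remains open how this assay responds to a phenyl ring carrying a methoxy, an amine or a carboxylic acid, or to a pyridine in place of the phenyl ring. Also open is whether the steps seen here hold when the 4-chlorophenyl ketone of the shared core is replaced, since every compound shown keeps it.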